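From trifluoromethyl to trifluoromethoxy on one aromatic ring

This account rests on a few compounds, and the source may have more. Where it says the series, first, only, none or still open, it means among the compounds named here.

Compound 2 `Oc1ccc(-c2cc(-c3ccccc3C(F)(F)F)cc(-c3ccccc3O)n2)cc1` was tested in a functional assay on DU-145 cells (Homo sapiens) for inhibition (a lower number here means a stronger inhibitor, a higher number a weaker inhibitor), where compound 2 gives 6690 nM. Within the data shown here, its only measured neighbour is compound 1 `Oc1cccc(-c2cc(-c3ccccc3C(F)(F)F)cc(-c3ccccc3O)n2)c1`, which in this assay gives 7250 nM, and the step of a 1.1-fold lower number from compound 1 to compound 2 (0.03 log units; within the scatter) lies within the scatter, so the two numbers stand side by side rather than apart. Compound 3 `Oc1ccc(-c2cc(-c3ccccc3OC(F)(F)F)cc(-c3ccccc3O)n2)cc1` has not yet been measured. It differs from compound 2 in one place: trifluoromethoxy in place of trifluoromethyl on an aromatic carbon. Among the measured compounds shown here, no measured step touches this group. For the measured compounds named here, the single step on record, a 1.1-fold lower number from compound 1 to compound 2 (0.03 log units; within the scatter), concerns the hydroxyphenyl ring and not the trifluoromethyl, so it bears on the present change only in showing that one substituent swap gave a result within the scatter in this assay. Going by the values given here, with no direct precedent, compound 3 is expected to sit close to compound 2, with an estimated step of a 1.0-fold higher number from compound 2 to compound 3 (0.00 log units; within the scatter) that should not exceed the scatter. The estimate for compound 3 in this assay is 6700 nM, with a range from 2800 nM to 16000 nM.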

Compound 3, half-maximal inhibitory concentration: 4190 nM
Beside the measured number, compound 3's estimate is 1.6-fold (0.20 log units) above it, within the range that was stated.
By their numbers in this assay, from the lowest: compounds 3, 2 and 1 (each within the scatter of the next).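

In this assay, among these compounds, the change from trifluoromethyl to trifluoromethoxy, on an aromatic carbon ortho to a large group, gives a 1.6-fold lower number from compound 2 to compound 3 (0.20 log units; within the scatter) and so provides the first measured step at this position. Adding the oxygen, which also brings one hydrogen-bond acceptor to this group, therefore produces no difference that this read-out can separate from the scatter, as also holds for the step on the hydroxyphenyl ring, a 1.1-fold lower number from compound 1 to compound 2 (0.03 log units; within the scatter). No measured information is available to explain the result at this position.

The compounds shown leave open whether this position would respond to a group of a different kind, such as an amine, a carboxylic acid or a longer chain, since trifluoromethyl and trifluoromethoxy are the only two groups seen there. From the compounds shown here alone, it also remains open whether trifluoromethoxy would give a similar step with the 3-hydroxyphenyl ring of compound 1 in place of the 4-hydroxyphenyl ring of compound 2.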